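Fluoro in place of acetamido: compound 2 to compound 3

The source may hold more compounds than are shown below. What is called first, only, known or untested is meant among the compounds shown, and "the series" means these compounds.

In an ADME assay on MDCK cells (Canis lupus familiaris) for cytotoxicity, read by MTT assay, with a stated time of 72 h (on this read-out higher numbers stand for lower toxicity in this test and lower numbers for higher toxicity in this test), compound 1 (`Cc1nc([N+](=O)[O-])cn1CC(=O)Nc1ccc(F)cc1`) gives 828000 nM. Compound 2 (`CC(=O)Nc1ccc(S(=O)(=O)n2cc([N+](=O)[O-])nc2C)cc1`) gives 1030000 nM, and these two numbers lie within the usual scatter of each other, so neither compound stands apart on this read-out. Compound 3 (`Cc1nc([N+](=O)[O-])cn1S(=O)(=O)c1ccc(F)cc1`), not yet measured, differs from compound 2 by carrying fluoro in place of acetamido on an aromatic carbon, para to a large group (fluoro in place of acetamido on an aromatic carbon). Among the measured compounds shown here, no measured pair isolates this change, so the expectation has little direct support. For the measured compounds named here, compound 1 also carries fluoro, and its 828000 nM is the only guide to a fluoro-bearing member of the series. No change beyond the scatter is expected in this assay. The estimated step is a 1.3-fold lower number from compound 2 to compound 3 (0.11 log units; within the scatter), small and downward. Compound 3 is expected at 800000 nM, with an estimated range of 350000 nM to 1500000 nM.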

Compound 3, half-maximal cytotoxic concentration: 813000 nM
Compound 3: middle estimate off by 1.0-fold (0.01 log units), on the low side; the range from low to high includes it.
By their numbers in this assay, from the lowest: compounds 3, 1 and 2 (each within the scatter of the next).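

In this assay, fluoro in place of acetamido on the aromatic carbon, para to a large group, gives a 1.3-fold lower number from compound 2 to compound 3 (0.10 log units; within the scatter). Among the compounds shown here, this is the first comparison that isolates a single place, and it shows that replacing acetamido, with its hydrogen-bond donor and acceptor, by fluoro, which has neither, does not move the read-out beyond the scatter. No supporting measurement bears on why compound 2 and compound 3 read alike.

Going by these compounds, whether an amine, a carboxylic acid or a longer chain at this position would also stay within the scatter remains open. With only acetamido and fluoro compared here, this single step gives no trend for the position and cannot show whether any group there would move this read-out.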